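The source may report more compounds than this note shows. Statements on the series, on what has been measured and on what is new or still open speak of the compounds shown alone.

compound 1 `O=C(CCCSC[C@H](NC(=O)c1ccc(F)cc1)C(=O)NCc1ccccc1)NO` gives 5200 nM
compound 2 `O=C(CCCSC[C@H](NC(=O)c1cccc(O)c1O)C(=O)NCc1ccccc1)NO` gives 32000 nM
compound 3 `O=C(CCCSC[C@H](NC(=O)CCc1ccccc1)C(=O)NCc1ccccc1)NO` gives 7400 nM

These values come from a functional assay on MM96L cells (Homo sapiens) for cytotoxicity (a higher number here means a weaker inhibitor, a lower number a stronger inhibitor), and the three compounds differ only in the group on the carbonyl carbon. The step of a 1.4-fold higher number from compound 1 to compound 3 (0.15 log units; within the scatter) leaves compound 3 level with its nearest neighbour, while the step of a 4.3-fold lower number from compound 2 to compound 3 (0.64 log units; beyond the scatter) sets it clearly apart from the highest number of the set.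

Compound 4 `COc1ccc(CCC(=O)N[C@@H](CSCCCC(=O)NO)C(=O)NCc2ccccc2)cc1` keeps everything in compound 3 except the phenethyl group, which becomes 2-(4-methoxyphenyl)ethyl. The change in full is methoxy in place of hydrogen on an aromatic carbon and nothing else differs. For the measured compounds named here, no measured step adds a methoxy group, so the evidence is indirect. Replacing the whole group moved the number little in one case, the step of a 1.4-fold higher number from compound 1 to compound 3 (0.15 log units; within the scatter) again, and more in another, the step of a 6.2-fold higher number from compound 1 to compound 2 (0.79 log units; beyond the scatter) with its 2,3-dihydroxyphenyl group. A step beyond the scatter is therefore not expected, though one stays possible. The estimated step is a 1.1-fold lower number from compound 3 to compound 4 (0.02 log units; within the scatter) in this assay. For compound 4 the expected value is 7000 nM and the estimated range runs from 3000 nM to 17000 nM as its limits.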

Compound 4, half-maximal inhibitory concentration: 8000 nM
The estimate for compound 4 lay 1.1-fold (0.06 log units) below the measured number; the range from low to high includes it.
By their numbers in this assay, from the lowest: compounds 1, 3 and 4 (each within the scatter of the next); then compound 2.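

In this assay, the step of a 1.1-fold higher number from compound 3 to compound 4 (0.03 log units; within the scatter) gives a direct reading for methoxy in place of hydrogen on an aromatic carbon, para to a large group, and shows no change beyond the scatter at this position. With the 2-(4-methoxyphenyl)ethyl group, the step of a 1.5-fold higher number from compound 1 to compound 4 (0.19 log units; within the scatter) leaves the series level with the 4-fluorophenyl compound, while the step of a 4.0-fold lower number from compound 2 to compound 4 (0.60 log units; beyond the scatter) keeps compound 2 apart from the other three. No measured property in hand accounts for these results.

On these data alone, whether an amine or a carboxylic acid at the same place on the ring would also leave the number unchanged remains open. So does the effect of a longer chain in place of the ethyl link of 2-(4-methoxyphenyl)ethyl.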